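The compounds below may be only part of what the source reports. "The series", "measured", "known", "first", "only" and "open" are said of these compounds alone.

In a functional assay on L1210 cells (Mus musculus) for inhibition (a lower number here means a stronger inhibitor, a higher number a weaker inhibitor), three compounds have been measured. Compound 1 `Cc1cn(C/C=C\CCl)c(=O)[nH]c1=O` gives 46000 nM, compound 2 `Nc1ncnc2c1ncn2C=C=CCCl` gives 45000 nM, and compound 3 `Cc1cn(C=C=CCO)c(=O)[nH]c1=O` gives 100000 nM. Compound 2 and compound 1 stand level within the scatter, while compound 3 lies beyond the scatter from compound 2, on the side of weaker inhibition.

The unmeasured compound 4 `Nc1ncnc2c1ncn2/C=C/CCO` keeps the core of compound 2 and differs only in the chain on the aromatic nitrogen: 4-hydroxybut-1-en-1-yl in place of 4-chlorobuta-1,2-dien-1-yl on an aromatic nitrogen. Here 4-hydroxybut-1-en-1-yl stands in place of 4-chlorobuta-1,2-dien-1-yl.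

Among the compounds with values here, no two measured compounds differ in one place only, so the size of this step cannot be read directly from the data. The closest guide is compound 3, whose chain ends in a hydroxyl group and which gives 100000 nM, although its core is that of compound 1 and not that of compound 2. On this thin evidence, a modest rise in the number is expected in this assay, towards weaker inhibition and slightly beyond the scatter. The estimated change is a 2.0-fold higher number from compound 2 to compound 4 (0.30 log units; within the scatter). For compound 4 the estimated value is 90000 nM, with an expected range from 35000 nM to 250000 nM.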

Compound 4, half-maximal inhibitory concentration: 100000 nM
Compound 4: middle estimate off by 1.1-fold (0.05 log units), on the low side, and the stated range covers the measured number.
By their numbers in this assay, from the lowest: compounds 2 and 1 (each within the scatter of the next); then compounds 3 and 4 (each within the scatter of the next).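

In this assay, within the data shown here, the replacement of 4-chlorobuta-1,2-dien-1-yl by 4-hydroxybut-1-en-1-yl on an aromatic nitrogen of the five-membered aromatic ring gives a 2.2-fold higher number from compound 2 to compound 4 (0.35 log units; beyond the scatter) and so provides the first reading of a change made in one place only, a modest move towards weaker inhibition that lies beyond the scatter. With the core held constant, the chain at this position is seen to affect the number, although this single step alters two things together: the chlorine gives way to a hydroxyl group, and the two double bonds outside aromatic rings become one. No measurement at hand bears on why the number moves.

It remains open which of these two differences carries the step, as the compounds shown do not pair the chlorine end with the single double bond, or the hydroxyl end with the two double bonds, on the core of compound 2. Also open, from the compounds shown here alone, is how a chain ending in an amine, or a longer chain, would read at this position on the same core.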